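The source may report more compounds than this note shows. Statements on the series, on what has been measured and on what is new or still open speak of the compounds shown alone.

Working notes on the series in a functional assay with Cavia porcellus as the target; on this read-out lower numbers stand for an effect already at smaller amounts and higher numbers for an effect only at larger amounts of compound.

Three compounds share the core. Compound 1 `COC(=O)c1c(C)[nH]c(C)c1C(=O)c1cc(Cl)ccc1Cl` gives 3980 nM, compound 2 `COC(=O)c1c(C)[nH]c(C)c1C(=O)c1ccccc1Cl` gives 14000 nM, and compound 3 `COC(=O)c1c(C(=O)c2ccccc2Cc2ccccc2)c[nH]c1C` gives 460 nM. Compound 2 stands highest of the three numbers; its nearest neighbour is compound 1, and compound 3 lies furthest from it. Among the measured compounds shown here, the one step between compounds that differ in a single place is a 3.5-fold higher number from compound 1 to compound 2 (0.55 log units; beyond the scatter), hydrogen in place of chloro on an aromatic carbon.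

Compound 4 `COC(=O)c1c(C)[nH]c(C)c1C(=O)c1ccccc1C(F)(F)F` is not yet measured. It differs from compound 2 by trifluoromethyl in place of chloro on an aromatic carbon; the place is on an aromatic carbon of a six-membered aromatic ring of carbon only, ortho to a large group.

For the measured compounds named here, no measured step exchanges chloro for trifluoromethyl, so the only bearing comes from a 3.5-fold higher number from compound 1 to compound 2 (0.55 log units; beyond the scatter), which shows that taking a chloro away from this ring raised the number by a modest amount. Restoring a group of four heavy atoms where a chloro stood may be expected to leave the number near that of compound 2 or lower it somewhat; the expected step is a 1.6-fold lower number from compound 2 to compound 4 (0.19 log units; within the scatter). Compound 4 is estimated at 9000 nM, with a range from 3000 nM to 30000 nM.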

Compound 4, half-maximal effective concentration: 4840 nM
Beside the measured number, compound 4's estimate is 1.9-fold (0.27 log units) above it, within the range that was stated.
By their numbers in this assay, from the lowest: compound 3; then compounds 1 and 4 (each within the scatter of the next); then compound 2.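

In this assay, among the compounds shown here, the exchange of chloro for trifluoromethyl gives a 2.9-fold lower number from compound 2 to compound 4 (0.46 log units; beyond the scatter), the first measured change on this aromatic carbon, ortho to a large group. The earlier step, a 3.5-fold higher number from compound 1 to compound 2 (0.55 log units; beyond the scatter), removed a different chloro from the ring, while the chloro at this place stayed in both compounds; the new result therefore shows that the number at this place responds to the group carried there, and that trifluoromethyl, with 4 heavy atoms in place of the single chlorine, goes with a lower number rather than a higher one. The data on hand give no measured property that would explain this step.

Two groups at one place cannot show whether the number follows the size of the group or some other feature of it, and a methyl, a methoxy, a nitrile or an amine at this same carbon would begin to separate these readings. On these data alone, it also remains open whether the same exchange would give a step of similar size in the presence of the second chloro carried by compound 1.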